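The compounds below may be only part of what the source reports. "The series", "measured", "known", "first", "only" and "open" are said of these compounds alone.

Measured compounds in an assay on isolated protein for inhibition of Dihydrofolate reductase (Mus musculus); a higher number here means a more potent compound, by a factor of ten per unit of this negative logarithm, a lower number a less potent compound:

compound 1 `CC1(C)N=C(N)N=C(N)N1c1ccc(CCC(=O)Nc2ccc(S(=O)(=O)F)cc2)c(Cl)c1` — 7.62
compound 2 `CC1(C)N=C(N)N=C(N)N1c1ccc(OCc2cccc(S(=O)(=O)F)c2Cl)c(Cl)c1` — 7.49

Compound 1 holds the higher of the two numbers in this assay; compound 2 sits lower by an amount that lies within the scatter, so the two values show no difference that can be read as an order. For the measured compounds named here, no pair of measured compounds differing in a single place is available, so no measured step exists to lean on.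

Compound 3 `CC1(C)N=C(N)N=C(N)N1c1ccc(CCC(=O)Nc2ccc(S(=O)(=O)F)cc2)cc1` is not yet measured. It differs from compound 1 in one place: hydrogen in place of chloro on an aromatic carbon. The rest of the shared core and the side chain are unchanged.

Going by the values given here, with no measured step of this kind, the expectation rests on the structural change alone. A modest fall in this assay is expected for compound 3 relative to compound 1, of a size at the edge of the scatter rather than far beyond it, the step from a number 0.42 log units lower from compound 1 to compound 3 (beyond the scatter) being the estimated shift. Compound 3 is estimated at 7.2, within a range from 6.6 to 7.7.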

Compound 3, logarithm of the reciprocal of the active concentration, log(1/C): 7.6
The estimate for compound 3 lay 0.40 log units below the measured number, within the range that was stated.
By their numbers in this assay, from the lowest: compounds 2, 3 and 1 (each within the scatter of the next).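

In this assay, for the compounds shown here, the exchange of chloro for hydrogen on an aromatic carbon supplies the first measured single-place step, a number 0.02 log units lower from compound 1 to compound 3 (within the scatter), so this pair shows no difference that can be read as an order. For this position, ortho to a large group and meta to a large group, and with the side chain of compound 1 kept unchanged, the chlorine can therefore leave without a readable consequence in this one pair, and compound 3 serves as a working reference without the chloro group. No measurement of any other kind is available to bear on this result.

It remains open whether the same exchange gives the same outcome with the side chain of compound 2, since the hydrogen counterpart of that compound is not among those shown. Also open, from the compounds shown here alone, is how other groups at this aromatic carbon, such as fluoro, methyl, methoxy, an amine or a carboxylic acid, would compare with chloro and hydrogen on the same side chain.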